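From Cyano to Ethoxycarbonyl at the Assay Limit

The source may report more compounds than this note shows. Statements on the series, on what has been measured and on what is new or still open speak of the compounds shown alone.

Compound 1 `C=C[C@@](C)(/C=C/c1ccc(O)c(/C=C/C(=O)OCC)c1)CCC=C(C)C` and compound 2 `COc1ccc(/C=C/[C@@](C)(/C=C/c2ccc(O)c(/C=C/C#N)c2)CCC=C(C)C)cc1` have both been tested in a functional assay on Raji cells (Homo sapiens) for cytotoxicity, with a stated time of 72 h; a lower number here means that less compound is needed, a higher number that more compound is needed for the effect. Compound 1 gives > 26000 nM, which is a limit of the assay and not a number. Compound 2 gives > 26000 nM, which is also a limit and not a number. Compound 2 therefore stands at the limit of > 26000 nM in this assay, at which 2 of the 2 values shown sit.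

Compound 3 `CCOC(=O)/C=C/c1cc(/C=C/[C@](C)(/C=C/c2ccc(OC)cc2)CCC=C(C)C)ccc1O` has not been measured yet. Compared with compound 2, it carries ethoxycarbonyl in place of cyano on a double-bonded chain carbon bound to a double-bonded chain carbon. The 2-(ethoxycarbonyl)ethenyl group also appears in compound 1, which gives > 26000 nM, again only a limit. Among the measured compounds shown here, no measured pair shows this change on its own, so any forecast is rough.

No shift beyond the usual scatter is expected in this assay, and the estimated step that the limit leaves unreadable from compound 2 to compound 3 reflects that. Another report of only a limit is the likeliest outcome. For compound 3 the expected value is 30000 nM, with an estimated range of 13000 nM to 60000 nM.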

Compound 3, half-maximal effective concentration: > 26000 nM
Compound 3 gave a limit, no number (the forecaster's own chance of this, stated with the estimate: 75%); the middle value is on the limit's open side.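

No step can be read between compound 3 and either compound 1 or compound 2, because all three results are limits and not numbers: the limit of > 26000 nM in this assay, at which 3 of the 3 values shown sit.

The compounds shown leave open whether ethoxycarbonyl in place of cyano, or 2-(4-methoxyphenyl)ethenyl in place of vinyl, changes the concentration needed for the effect at all.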